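The compounds below may be only part of what the source reports. "The series", "measured", "known", "first", "only" and "open" are said of these compounds alone.

Measured in a functional assay on the whole organism (strain CD1) with Mus musculus as the target, in the maximal electroshock model, with a stated time of 0.5 h; a higher number here means that more compound is needed for the effect, a lower number that less compound is needed:

Compound 1, `CC1CC(=O)N(CC(=O)N2CCN(c3ccc(F)cc3)CC2)C1=O`: 300 mg/kg
Compound 2, `CC1CC(=O)N(CC(=O)N2CCN(c3cccc(Cl)c3)CC2)C1=O`: 100 mg/kg
Compound 3, `Cc1ccccc1N1CCN(C(=O)CN2C(=O)CC(C)C2=O)CC1`: 300 mg/kg

Compound 1 stands level with compound 3 at the digits printed, and together they show the highest numbers of the three, so the most compound is needed for them. Its nearest neighbour is compound 3, with no change at the digits printed from compound 1 to compound 3 (within the scatter), and its furthest is compound 2, with a 3.0-fold lower number from compound 1 to compound 2 (0.48 log units; beyond the scatter). Between the other two, a 3.0-fold higher number from compound 2 to compound 3 (0.48 log units; beyond the scatter).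

Compound 4, `CCC1(C)CC(=O)N(CC(=O)N2CCN(c3ccc(F)cc3)CC2)C1=O`, differs from compound 1 in one place: ethyl in place of hydrogen on a saturated ring carbon. Among the measured compounds shown here, all three measured steps change only the group on the amine nitrogen in a ring; none of them touches the saturated ring carbon of the shared core, so no measured step bears directly on this change. What is known is only that variation at the aryl end moves this assay by modest amounts, and this gives no ground to expect a step beyond the scatter here. The account therefore expects compound 4 to remain close to compound 1, with a wide range to reflect the absence of a comparable step.

Compound 4 is estimated at 300 mg/kg, within 100 mg/kg to 600 mg/kg. For compound 4 the expected step is no change at the digits printed from compound 1 to compound 4 (within the scatter).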

Compound 4, minimum effective dose: 100 mg/kg
Compound 4: middle estimate off by 3.0-fold (0.48 log units), on the high side, within the range that was stated.
By their numbers in this assay, from the lowest: compounds 2 and 4 (each within the scatter of the next); then compounds 1 and 3 (each within the scatter of the next).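

In this assay, the saturated ring carbon two ring bonds from the ring nitrogen proves to be a place where the number can move: ethyl in place of hydrogen gives a 3.0-fold lower number from compound 1 to compound 4 (0.48 log units; beyond the scatter). The earlier steps shown here changed only the group on an amine nitrogen in a ring, so they showed sensitivity at that end alone; this step shows that a change of 2 carbon atoms in the shared core can also lower the dose needed, and by a step of the same printed size as a 3.0-fold lower number from compound 1 to compound 2 (0.48 log units; beyond the scatter). Nothing available explains why this ethyl group lowers the number.

The compounds shown leave open whether the step depends on ethyl itself or would also appear, or grow, with a longer chain such as propyl or with a polar group such as an amine on the same carbon. They also leave open whether ethyl would lower the number to the same extent with 3-chlorophenyl or 2-methylphenyl in place of 4-fluorophenyl on the amine nitrogen in a ring, as the step is seen with 4-fluorophenyl alone.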